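Swapping the Aryl Arm on a Shared Core

The source may hold more compounds than are shown below. What is called first, only, known or untested is meant among the compounds shown, and "the series" means these compounds.

Compound 1, `O=C1N=C(N2CCC[C@H]2C(=O)Nc2ccc3ncnc(Nc4cccc(Cl)c4)c3c2)S/C1=C/c1ccc(-c2ccccc2)cc1`, in a functional assay on HepG2 cells (Homo sapiens) for antiproliferative activity, read by MTT assay (a lower number here means a stronger inhibitor, a higher number a weaker inhibitor), gives 15400 nM.
Compound 2, `O=C1N=C(N2CCC[C@H]2C(=O)Nc2ccc3ncnc(Nc4cccc(Cl)c4)c3c2)S/C1=C/c1cccc(Br)n1`, in this assay gives 2700 nM.

Going by the values given here, compound 2 holds the lower of the two numbers measured so far, and its nearest neighbour is compound 1, the gap being a 5.7-fold lower number from compound 1 to compound 2 (0.76 log units; beyond the scatter). Compound 3, `COc1ccccc1/C=C1/SC(N2CCC[C@H]2C(=O)Nc2ccc3ncnc(Nc4cccc(Cl)c4)c3c2)=NC1=O`, has not yet been measured. It differs from compound 2 in one place only: 2-methoxyphenyl in place of 6-bromopyridin-2-yl on a double-bonded chain carbon bound to a double-bonded ring carbon. Among the compounds with values here, the single measured step that touches this place is a 5.7-fold lower number from compound 1 to compound 2 (0.76 log units; beyond the scatter), where a two-ring carbon group gave way to the bromopyridinyl ring and the number fell well beyond the scatter. The incoming 2-methoxyphenyl is a one-ring carbon group, so compound 3 is expected to land between the two measured compounds, a modest rise from compound 2, a 1.9-fold higher number from compound 2 to compound 3 (0.27 log units; within the scatter). In this assay compound 3 is therefore estimated at 5000 nM, within a range of 1500 nM to 16000 nM.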

Compound 3, half-maximal inhibitory concentration: 22100 nM
The estimate for compound 3 lay 4.4-fold (0.65 log units) below the measured number; the whole stated range lies below it.
By their numbers in this assay, from the lowest: compound 2; then compounds 1 and 3 (each within the scatter of the next).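

Replacing 6-bromopyridin-2-yl with 2-methoxyphenyl gives an 8.2-fold higher number from compound 2 to compound 3 (0.91 log units; beyond the scatter) in this assay, so having one six-membered aromatic ring at this place does not by itself keep the number low. Against the larger 4-phenylphenyl, the same 2-methoxyphenyl gives a 1.4-fold higher number from compound 1 to compound 3 (0.16 log units; within the scatter), so among these three compounds only compound 2 stands apart, and group size does not sort the numbers. The change swaps nitrogen and bromine for oxygen and additional carbon, and no available evidence links the shift in the number to any one of these differences.

On these data alone, it remains open whether the gain in compound 2 needs the ring nitrogen, the bromine or both, which a plain pyridin-2-yl ring could help to separate. As far as these compounds go, how an aromatic ring carrying an amine or a carboxylic acid would behave here is also open.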